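Shortening the Chain from Propyl to Ethyl

This account rests on a few compounds, and the source may have more. Where it says the series, first, only, none or still open, it means among the compounds named here.

Compound 3 `CCCc1cnc2c(C#N)c(N3CCN(c4nc(C)cc(C)n4)CC3)ccn12` is one of three compounds examined in a functional assay on CHO cells with metabotropic glutamate receptor 2 (Homo sapiens) as the target, read by GTPgammaS binding; on this read-out lower numbers stand for an effect already at smaller amounts and higher numbers for an effect only at larger amounts of compound. Compound 3 gives 646 nM. Compound 2 `Cc1cc(C)nc(N2CCN(c3ccn4c(CC(F)(F)F)cnc4c3C#N)CC2)n1` gives 447 nM, and the gap between them is within the scatter: a 1.4-fold higher number from compound 2 to compound 3 (0.16 log units; within the scatter). Compound 1 `CCc1cnc2c(C#N)c(N3CCN(c4ncccn4)CC3)ccn12` gives only a limit in this assay, > 3160 nM (the limit of > 3160 nM in this assay, at which 1 of the 3 values shown sits). Compound 4 `CCc1cnc2c(C#N)c(N3CCN(c4nc(C)cc(C)n4)CC3)ccn12` differs from compound 3 in one place: hydrogen in place of methyl on a saturated chain carbon, two bonds along the chain from an aromatic carbon. Read one bond further out, the chain goes from propyl to ethyl. No measured step alters this chain by a single saturated carbon; the only step shown, from compound 2 to compound 3, exchanges trifluoromethyl for ethyl and stays within the scatter, so it says nothing about the propyl to ethyl cut. Compound 1 carries ethyl but differs elsewhere as well, so its limit does not isolate the change. Compound 4 is therefore expected to sit near compound 3, with the step of a 1.2-fold higher number from compound 3 to compound 4 (0.09 log units; within the scatter) estimated small and of uncertain direction. The estimate for compound 4 is 800 nM, from 300 nM to 2500 nM.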

Compound 4, half-maximal effective concentration: 2290 nM
For compound 4 the middle estimate is 2.9-fold (0.46 log units) below the measured one; measured number inside the range.
By their numbers in this assay, from the lowest: compounds 2 and 3 (each within the scatter of the next); then compound 4. At a limit, above all of these: compound 1.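

In this assay, the chain at this position turns out to matter: cutting propyl to ethyl gives a 3.5-fold higher number from compound 3 to compound 4 (0.55 log units; beyond the scatter), whereas the earlier comparison held only a 1.4-fold higher number from compound 2 to compound 3 (0.16 log units; within the scatter). Methyl in place of trifluoromethyl on the same saturated chain carbon gives a 5.1-fold higher number from compound 2 to compound 4 (0.71 log units; beyond the scatter), so among these compounds ethyl and trifluoromethyl at that carbon stay within the scatter of each other, while methyl there does not. 4,6-Dimethylpyrimidin-2-yl in place of pyrimidin-2-yl can be read only as a floor, an at least 1.3-fold lower number from compound 1 to compound 4 (0.13 log units; that floor lies within the scatter). Compound 1 gives only a limit: the limit of > 3160 nM in this assay, at which 1 of the 4 values shown sits.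

As far as these compounds go, whether a longer chain such as butyl would hold the number near that of compound 3 remains open, as does the effect of a hydroxyl or an amine at the end of the chain. From the compounds shown here alone, it is also open whether the propyl to ethyl cut has the same size with pyrimidin-2-yl in place of 4,6-dimethylpyrimidin-2-yl.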